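A Dimethylamino Group on Compound 3

The compounds below may be only part of what the source reports. "The series", "measured", "known", "first", "only" and "open" are said of these compounds alone.

Three compounds sharing one core have numbers for antiproliferative activity. In a functional assay on DU-145 cells (Homo sapiens) for antiproliferative activity, read by MTT assay, with a stated time of 48 h (on this read-out higher numbers stand for weaker inhibition and lower numbers for stronger inhibition), compound 1 (`Brc1ccc(-c2nnc(-c3cn4ccccc4n3)o2)cc1`) reaches only a limit of the assay (> 50000 nM), not a number. In this assay compound 2 (`Cc1cccn2cc(-c3nnc(-c4ccccc4I)o3)nc12`) gives 31500 nM and compound 3 (`Cc1cc(Br)c2nc(-c3nnc(-c4ccccc4)o3)cn2c1`) gives 18900 nM on the same read-out. These two values lie within the usual scatter of each other, so the numbers do not separate compound 3 from compound 2.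

Compound 4 (`Cc1cc(Br)c2nc(-c3nnc(-c4ccc(N(C)C)cc4)o3)cn2c1`) is compound 3 with dimethylamino in place of hydrogen on an aromatic carbon of a six-membered aromatic ring of carbon only, para to a large group (dimethylamino in place of hydrogen on an aromatic carbon). Among the compounds with values here, no two measured compounds differ in just one place, so the data offer no direct step for this change. The expectation therefore rests only on compound 3 at 18900 nM and gives no reason to foresee a large move. The estimated step in this assay is a 1.4-fold lower number from compound 3 to compound 4 (0.13 log units; within the scatter), a small shift toward stronger inhibition that is expected to stay within the scatter. For compound 4 the expected value is 14000 nM, with an estimated range from 4000 nM to 45000 nM in this read-out.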

Compound 4, half-maximal inhibitory concentration: 12800 nM
Estimate against measurement, compound 4: 1.1-fold (0.04 log units) above; the measured number falls inside the stated range.
By their numbers in this assay, from the lowest: compounds 4, 3 and 2 (each within the scatter of the next, the first and the last beyond it). At a limit, above all of these: compound 1.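

Placing dimethylamino in place of hydrogen on an aromatic carbon, para to a large group, gives a 1.5-fold lower number from compound 3 to compound 4 (0.17 log units; within the scatter) in this assay, and this is the first comparison in the series between two compounds that differ in one place. It shows that this position of the six-membered aromatic ring of carbon only can carry dimethylamino and still return a number, while the step stays too small to separate compound 4 from compound 3 on this read-out. Compound 1 alone stands at a limit of the assay, not at a number: the limit of > 50000 nM in this assay, at which 1 of the 4 values shown sits.

Within the data shown here, what a primary amine, a methoxy group or a carboxylic acid would do on this same aromatic carbon stays open, so the single step cannot say whether any group here moves the number beyond the scatter. Going by these compounds, it is equally open whether dimethylamino would give a similar step on a compound with a different substitution of the shared core, such as the core of compound 2.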